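Replacing one ring group on compound 3

The compounds below may be only part of what the source reports. "The series", "measured", "known", "first", "only" and "open" are said of these compounds alone.

In an ADME assay on Caco-2 cells (Homo sapiens) for permeability, read by LC-MS, with a stated time of 2 h (on this read-out lower numbers stand for lower permeability and higher numbers for higher permeability), compound 3 `COc1cc(CN(CC(C)C)C(CC(=O)O)c2ccc3c(c2)CCO3)ccc1OCCN1C(=O)CCC1=O` gives 0.2 nm/s, the lower of the two numbers available. Compound 1 `Cc1cc(CN(CC2CC2)[C@@H](CC(=O)O)c2ccc(Cl)cc2)ccc1OCCN1C(=O)CCC1=O` gives 7.3 nm/s, a gap well beyond the usual scatter, while the result for compound 2 `Cc1cc(CN(CCC(F)(F)F)C(CC(=O)O)c2ccc(Cl)cc2)ccc1OCCN1C(=O)CCC1=O` is "not determined" (no result reported). Compound 4 `COc1cc(CN(CC(C)C)C(CC(=O)O)c2ccc(Cl)cc2Cl)ccc1OCCN1C(=O)CCC1=O` differs from compound 3 in one place: a group of 8 heavy atoms (6 carbon, 2 chlorine; one six-membered aromatic ring of carbon only) in place of a group of 9 heavy atoms (8 carbon, 1 oxygen; one five-membered non-aromatic ring with 1 hetero atom, one six-membered aromatic ring of carbon only), on a saturated chain carbon bound to an amine nitrogen and a saturated chain carbon. The entering group is 2,4-dichlorophenyl. Going by the values given here, no measured pair differs in only one place, so the size of this step remains uncertain. Compound 1 also carries chlorine and gives 7.3 nm/s, but it differs from compound 3 elsewhere too, so only a moderate rise is expected in this assay. The expected change is a 7.5-fold higher number from compound 3 to compound 4 (0.88 log units; beyond the scatter). For compound 4 the estimated value is 1.5 nm/s, with an expected range of 0.3 nm/s to 8 nm/s.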

Compound 4, apparent permeability: 28.1 nm/s
Beside the measured number, compound 4's estimate is 19-fold (1.27 log units) below it; measured number above the stated range.
By their numbers in this assay, from the lowest: compound 3; then compound 1; then compound 4.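

In this assay, going by these compounds alone, the change on the saturated chain carbon bound to an amine nitrogen gives a 140-fold higher number from compound 3 to compound 4 (2.15 log units; beyond the scatter), the first step here read with the rest of the structure held fixed. It shows that this one group alone can move the read-out by a large amount, with the entering 2,4-dichlorophenyl giving the higher number. Nothing measured here explains the rise.

Whether one chlorine would give a similar number remains open, as 2-chlorophenyl is not among these compounds. On these data alone, how a pyridine ring would behave on this carbon is also open.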